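The source may report more compounds than this note shows. Statements on the series, on what has been measured and on what is new or still open speak of the compounds shown alone.

In a physicochemical assay for solubility, at pH 1.1 (on this read-out higher numbers stand for higher solubility and lower numbers for lower solubility), compound 1 `COc1cc(CN(CC(C)C)C(CC(=O)O)c2ccc3c(c2)CCO3)ccc1OCCN1C(=O)CCC1=O` gives 3000000 nM and compound 2 `COc1cc(CN(CC(C)C)C(CC(=O)O)c2ccc(Cl)cc2)ccc1OCCN1C(=O)CCC1=O` gives 3000000 nM, so compound 2 stands level with compound 1. Compound 3 `COc1cc(CN(CC(C)C)C(CC(=O)O)c2ccc(Cl)c(Cl)c2)ccc1OCCN1C(=O)CCC1=O` has not yet been measured. It differs from compound 2 in a single place: chloro in place of hydrogen on an aromatic carbon. In words, chloro takes the place of hydrogen on an aromatic carbon, a change that can also be read as 4-chlorophenyl to 3,4-dichlorophenyl.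

Among the compounds with values here, only one measured step bears on this change, and only loosely: no change at the digits printed from compound 1 to compound 2 (within the scatter). That step exchanges a whole group, while the new change adds one chloro to the group found in compound 2. Within the data shown here, no measured pair shows the addition of a chloro on its own, so the guidance is thin. Among the measured compounds shown here, since the single step available, no change at the digits printed from compound 1 to compound 2 (within the scatter), stayed within the scatter, no step beyond the scatter is expected in this assay, in either direction. The expected move is no change at the digits printed from compound 2 to compound 3 (within the scatter). For compound 3 the estimated value is 3000000 nM, with an expected range from 1200000 nM to 4000000 nM.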

Compound 3, solubility: 3000000 nM
Estimate against measurement, compound 3: no gap at the digits printed; measured number inside the range.
By their numbers in this assay, from the lowest: compounds 1, 2 and 3 (each within the scatter of the next).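

Adding a single chloro on this aromatic carbon, ortho to the chloro group already on the ring, gives no change at the digits printed from compound 2 to compound 3 (within the scatter) in this assay. Within the data shown here, this is the first direct reading of one small addition at this position, whereas the earlier step exchanged a whole group at once. The larger exchange, with 3,4-dichlorophenyl as the incoming group, also gives no change at the digits printed from compound 1 to compound 3 (within the scatter), so the two exchanges at this saturated chain carbon now read alike, and no measurement shown offers an explanation for this flat picture.

The compounds shown leave open whether the level result belongs to chloro alone or would also hold for quite different groups on the same aromatic carbon, such as a nitrile, a hydroxyl or a primary amine. They also leave open how this read-out would respond to a change elsewhere in the molecule, for example a longer chain in place of the one on the amine nitrogen, since all three compounds share that part of the structure.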